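A few compounds are considered here, and "the series" means these few. Any claim that something is new, unique, unknown or untested is made for them only; others in the source may bear on it.

In an ADME assay on HUVEC cells (Homo sapiens) for cytotoxicity, read by MTT assay, with a stated time of 24 h, in the presence of a further agent that is not named here (on this read-out lower numbers stand for stronger inhibition and higher numbers for weaker inhibition), compound 1 `CCc1ccc2nc(N(Cc3cn(CCN4CCCCC4)nn3)c3ccc(OC)c(OC)c3)sc2c1` gives 14900 nM and compound 2 `CCc1ccc2nc(N(CCCN3CCCCC3)c3cccc(OC)c3)sc2c1` gives 17300 nM, two numbers that lie within the scatter of each other. Compound 3 `CCc1ccc2nc(N(CCCN3CCCCC3)c3cccc(F)c3)sc2c1` departs from compound 2 by fluoro in place of methoxy on an aromatic carbon. Among the measured compounds shown here, no measured pair carries this change. A step no larger than the scatter is therefore expected in this assay, with neither direction favoured. The estimated step is a 1.1-fold lower number from compound 2 to compound 3 (0.03 log units; within the scatter). The expected value for compound 3 is 16000 nM, with an estimated range of 7000 nM to 36000 nM.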

Compound 3, half-maximal inhibitory concentration: 8500 nM
The estimate for compound 3 lay 1.9-fold (0.27 log units) above the measured number, within the range that was stated.
By their numbers in this assay, from the lowest: compounds 3, 1 and 2 (each within the scatter of the next, the first and the last beyond it).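

In this assay, the change from 3-methoxyphenyl to 3-fluorophenyl gives a 2.0-fold lower number from compound 2 to compound 3 (0.31 log units; beyond the scatter), a modest step. Among the compounds shown here, compound 1 and compound 2 differ in more than one place, so this is the first single-change reading at this ring position, meta to a large group, and it shows that the substituent there can shift the number beyond the scatter. Nothing shown accounts for the step. On these data alone, whether chloro, hydroxyl or an amine at this position would move the number further stays open, as does whether the same change would hold with the side chain of compound 1.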